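Taking the tert-butyl off compound 2

The compounds below may be only part of what the source reports. "The series", "measured", "known", "first", "only" and "open" are said of these compounds alone.

Measured in a physicochemical assay for solubility, in phosphate buffer, at pH 7.4; a higher number here means a more soluble compound, a lower number a less soluble compound:
Compound 1 `CCOC(=O)c1c(-c2ccc(OC)cc2)[nH]c2cccc(OC)c2c1=O`: > 100000 nM (a limit)
Compound 2 `CCOC(=O)c1c(-c2ccc(C(C)(C)C)cc2)[nH]c2cccc(OC)c2c1=O`: 1000 nM
Compound 3 `CCOC(=O)c1c(-c2cccc([N+](=O)[O-])c2)[nH]c2cc(OC)ccc2c1=O`: 13000 nM

Compound 2, at 1000 nM, has the lowest number shown. The nearest is compound 3, with a higher number, at 13000 nM. That gap lies beyond the scatter. Compound 1 sits at > 100000 nM, which is a limit of the assay and not a number.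

Compound 4 `CCOC(=O)c1c(-c2ccccc2)[nH]c2cccc(OC)c2c1=O` has hydrogen in place of tert-butyl on an aromatic carbon. Among the measured compounds shown here, one measured step bears on this: an at least 100-fold lower number from compound 1 to compound 2 (2.00 log units; beyond the scatter), a large step that rests on (the limit of > 100000 nM in this assay, at which 1 of the 3 values shown sits). It put tert-butyl in place of methoxy, so it is not the exact reverse of this change. Even so, a large rise in this assay is expected. The expected step is a 20-fold higher number from compound 2 to compound 4 (1.30 log units; beyond the scatter). For compound 4 the estimated value is 20000 nM, within an expected range of 5000 nM to 80000 nM.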

Compound 4, solubility: > 100000 nM
Compound 4 was reported as a limit (the forecaster's own chance of this, stated with the estimate: 10%); at least 5.0-fold (0.69 log units) between middle value and limit.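

In this assay, hydrogen in place of tert-butyl gives an at least 100-fold higher number from compound 2 to compound 4 (2.00 log units; beyond the scatter), and the size of this step rests on a limit: the limit of > 100000 nM in this assay, at which 2 of the 4 values shown sit. Compound 4 stands at > 100000 nM, which is a limit of the assay and not a number. The low number of compound 2 now stands out against hydrogen as well as against methoxy at this position.

The step from compound 1 to compound 4 cannot be read, as both values are limits. On these data alone, how an amine or a carboxylic acid would read at this position remains open.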